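A few compounds are considered here, and "the series" means these few. Any claim that something is new, unique, unknown or untested is made for them only; others in the source may bear on it.

Measured so far:
compound 1, `CNC(=O)c1cc(C(=O)NC2CC2)cn([C@H](C)c2ccccc2)c1=O`: >= 168 ug/mL
compound 2, `CNC(=O)c1cc(C(=O)NC2CC2)cn(Cc2cccc3[nH]ncc23)c1=O`: 10 ug/mL

Within the data shown here, in a physicochemical assay for solubility (a higher number here means a more soluble compound, a lower number a less soluble compound), compound 2 gives 10 ug/mL, the only plain number among the two values shown. Compound 1 gives >= 168 ug/mL, which is a limit of the assay rather than a number (the limit of >= 168 ug/mL in this assay, at which 1 of the 2 values shown sits). Compound 3, `CNC(=O)c1cc(C(=O)NC2CC2)cn(Cc2ccccc2F)c1=O`, has not yet been measured in this assay. It differs from compound 2 in one place: 2-fluorophenyl in place of 1H-indazol-4-yl on a saturated chain carbon bound to an aromatic nitrogen. Among the measured compounds shown here, no step between two measured compounds is available here, so the size of this change cannot be read off a matched pair and has to be estimated. A rise in this assay beyond the usual scatter is expected: a 9.0-fold higher number from compound 2 to compound 3 (0.95 log units; beyond the scatter). Compound 3 is estimated at 90 ug/mL, within a range from 30 ug/mL to 200 ug/mL. It is also possible that the assay reports only a limit for compound 3 rather than a number.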

Compound 3, solubility: >= 145 ug/mL
Compound 3 ended at the assay's limit; the forecaster's own chance of this, stated with the estimate: 30%; at least 1.6-fold (0.20 log units) between middle value and limit.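

In this assay, putting 2-fluorophenyl in place of 1H-indazol-4-yl on a saturated chain carbon bound to an aromatic nitrogen gives an at least 14-fold higher number from compound 2 to compound 3 (1.16 log units; beyond the scatter), the first size that can be read for a change at this place. The value of compound 3 is a limit of the assay and not a number, so this step gives only the smallest size the change can have: the limit of >= 145 ug/mL in this assay, at which 1 of the 3 values shown sits. The step from compound 1 to compound 3 cannot be read.

From the compounds shown here alone, how far the true number of compound 3 lies past its limit stays open, and so does the question of whether the fluorine contributes to the step or the change of ring alone accounts for it. An unsubstituted phenyl or a pyridine ring at this place could help separate those two parts of the change.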